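The source may report more compounds than this note shows. Statements on the series, on what has been measured and on what is new or still open speak of the compounds shown alone.

Compound 1 `O=[N+]([O-])c1cccc(CNc2cc(Br)cc3[nH]ncc23)c1` carries a bromo group on its shared core. In an assay for inhibition of Indoleamine 2,3-dioxygenase 1 (Homo sapiens), with stated times of 10 min and 60 min (on this read-out lower numbers stand for stronger inhibition and higher numbers for weaker inhibition), compound 1 gives 7950 nM. Compound 2 `O=[N+]([O-])c1cccc(CNc2cc(C(F)(F)F)cc3[nH]ncc23)c1` differs from it by trifluoromethyl in place of bromo on an aromatic carbon. In this assay compound 2 reaches only a limit of the assay, > 100000 nM. The step of an at least 12-fold higher number from compound 1 to compound 2 (1.09 log units; beyond the scatter) is therefore known only as a minimum, because compound 2 sits at the limit of > 100000 nM in this assay, at which 1 of the 3 values shown sits.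

Compound 3 `O=[N+]([O-])c1ccc(CNc2cc(Br)cc3[nH]ncc23)cc1` has the same atoms as compound 1, joined differently; the difference between the two cores is not broken down here. In this assay compound 3 gives 6970 nM, a value within the usual scatter of compound 1, so the two cannot be told apart.

Compound 4 `O=[N+]([O-])c1ccc(CNc2cc(C(F)(F)F)cc3[nH]ncc23)cc1` stands to compound 3 as compound 2 stands to compound 1: trifluoromethyl in place of bromo on an aromatic carbon, at a place described in the same words, so it is the same change. The step of a 17-fold higher number from compound 3 to compound 4 (1.24 log units; beyond the scatter) is expected to resemble the earlier one, resting on an at least 12-fold higher number from compound 1 to compound 2 (1.09 log units; beyond the scatter) and on compound 3 sitting close to compound 1. Compound 4 is estimated at about 120000 nM, plausibly between 40000 nM and 400000 nM, and may again appear only as a limit.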

Compound 4, half-maximal inhibitory concentration: 61000 nM
Estimate against measurement, compound 4: 2.0-fold (0.29 log units) above; measured number inside the range.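

Putting trifluoromethyl in place of bromo on the core of compound 3 gives an 8.8-fold higher number from compound 3 to compound 4 (0.94 log units; beyond the scatter) in this assay, so the change goes the same way on both cores shown, and on each the number rises beyond the scatter. This shows that the direction of the step carried over from one core to the other, but it does not show that the size carried over as well: the same change on two cores in this assay, an at least 12-fold higher number (1.09 log units; beyond the scatter) from compound 1 to compound 2 and an 8.8-fold higher number (0.94 log units; beyond the scatter) from compound 3 to compound 4; the limit leaves it open whether they differ The step on the core of compound 1 stays a minimum, and compound 2 gives no exact number, since its value is a limit: the limit of > 100000 nM in this assay, at which 1 of the 4 values shown sits.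

The compounds shown hold only bromo and trifluoromethyl at this place, so they leave open how an amine, a carboxylic acid or a simple methyl group there would read in this assay. They also leave open whether the same change would go the same way on any core beyond these two.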